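The source may report more compounds than this note shows. Statements on the series, on what has been measured and on what is new or still open speak of the compounds shown alone.

Of the compounds shown here, three have been measured in an ADME assay on PA-1 cells (Homo sapiens) for cytotoxicity, read by MTT assay, with a stated time of 72 h (on this read-out higher numbers stand for weaker inhibition and lower numbers for stronger inhibition), and none of them gave a number. Compound 1 `COc1ccc(C2=C(c3cc(OC)c(OC)c(OC)c3)C(=O)C(OC(C)=O)C2)cc1F` sits at the assay limit of > 100 ug/mL in this assay. Compound 2 `COc1ccc(C2=C(c3cc(OC)c(OC)c(OC)c3)C(=O)CC2O[SiH2]C(C)(C)C)cc1OC` also reaches only the limit of > 100 ug/mL in this assay. Compound 3 `COc1ccc(C2=C(c3cc(OC)c(OC)c(OC)c3)CC(O[SiH2]C(C)(C)C)C2=O)cc1[N+](=O)[O-]` is likewise reported at the limit of > 100 ug/mL in this assay. Compound 3 therefore stands where every measured compound stands, at the limit of > 100 ug/mL in this assay, at which 3 of the 3 values shown sit, with no ordering among them possible.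

Compound 4 `COc1ccc(C2=C(c3cc(OC)c(OC)c(OC)c3)CC(O)C2=O)cc1[N+](=O)[O-]` differs from compound 3 in one place: a hydrogen atom in place of a group of 5 heavy atoms (4 carbon, 1 silicon; no ring), on an oxygen on a saturated carbon. Among the measured compounds shown here, no step between two measured compounds is available, so the size of this change cannot be read from the data. With all three measured compounds at the limit, the expected step from compound 3 to compound 4 in this assay is a number no higher from compound 3 to compound 4 (the limit leaves the size open), meaning none beyond the scatter. Compound 4 is accordingly estimated at 100 ug/mL in this assay, within a range from 30 ug/mL to 300 ug/mL, with a high chance that only a limit is reported again.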

Compound 4, half-maximal inhibitory concentration: > 100 ug/mL
Compound 4 gave a limit, no number; the forecaster's own chance of this, stated with the estimate: 65%; the middle value sits exactly at the limit.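

No step can be read between compound 3 and compound 4, as each gives only a limit in this assay and not a number: the limit of > 100 ug/mL in this assay, at which 4 of the 4 values shown sit. The compounds shown leave open whether any change to the shared core would give a measurable value in this read-out.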